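The source may report more compounds than this note shows. Statements on the series, on what has been measured and on what is new or still open speak of the compounds shown alone.

Three compounds of one family have been examined for how strongly they damage cultured cells, in an ADME assay on Vero cells (Chlorocebus sabaeus) for cytotoxicity; on this read-out higher numbers stand for lower toxicity in this test and lower numbers for higher toxicity in this test. Compound 1 `O=C(O)c1cccc(-c2ccc(/C=C3\S/C(=N\c4ccccc4)N(c4ccc(F)cn4)C3=O)o2)c1` carries a 5-fluoropyridin-2-yl group on an amide-type nitrogen in a ring of its shared core. In this assay compound 1 gives > 200000 nM, which is a limit of the assay rather than a number. Compound 2 `O=C(O)c1cccc(-c2ccc(/C=C3\S/C(=N\c4ccccc4)N(c4ccc(F)cn4)C3=O)s2)c1` rests on a different core; the difference between the two cores is not broken down here. In this assay compound 2 gives > 200000 nM, again a limit and not a number. Compound 3 `O=C(O)c1cccc(-c2ccc(/C=C3\S/C(=N\c4ccccc4)N(c4cccnc4Cl)C3=O)o2)c1` differs from compound 1 in a single place: 2-chloropyridin-3-yl in place of 5-fluoropyridin-2-yl on an amide-type nitrogen in a ring. In this assay compound 3 gives > 200000 nM, also a limit. The step that the two limits leave unreadable from compound 1 to compound 3 is therefore unreadable because of the limit of > 200000 nM in this assay, at which 3 of the 3 values shown sit. Compound 4 `O=C(O)c1cccc(-c2ccc(/C=C3\S/C(=N\c4ccccc4)N(c4cccnc4Cl)C3=O)s2)c1` carries the same change on the core of compound 2: 2-chloropyridin-3-yl in place of 5-fluoropyridin-2-yl on an amide-type nitrogen in a ring. The step from compound 2 to compound 4 is expected to be a step that the limit leaves unreadable from compound 2 to compound 4, an expectation resting on the unreadable step that the two limits leave unreadable from compound 1 to compound 3. It also rests on the limit shown by compound 2 of > 200000 nM. Compound 4 is thus estimated at 300000 nM, expected to lie between 150000 nM and 1000000 nM.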

Compound 4, half-maximal cytotoxic concentration: > 200000 nM
Compound 4 was reported as a limit (the forecaster's own chance of this, stated with the estimate: 85%); the middle value lies beyond the limit too.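

Putting 2-chloropyridin-3-yl in place of 5-fluoropyridin-2-yl takes compound 2 to compound 4, but this gives no readable step, because both results are limits and not numbers: the limit of > 200000 nM in this assay, at which 4 of the 4 values shown sit. The compounds shown leave open how far they truly differ in this assay and what concentration of any of them would damage these cells.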